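Phenylcarbamoyl in Place of Dimethylamino on a Poorly Soluble Core

A few compounds are considered here, and "the series" means these few. Any claim that something is new, unique, unknown or untested is made for them only; others in the source may bear on it.

Compound 1 `Cc1cc(NCc2ccccn2)n2ncc(-c3ccc(N(C)C)cc3)c2n1` stands at a limit in a physicochemical assay for solubility, read by HPLC, using the shake flask method, measured as kinetic solubility, with a stated time of 2 h, at pH 7.4; a lower number here means a less soluble compound, a higher number a more soluble compound: its reading of < 5000 nM is a limit of the assay, not a number. Compound 2 `Cc1cc(NCc2ccccn2)n2ncc(-c3ccc(F)c(Cl)c3)c2n1` likewise gives only a limit, < 5000 nM, in this assay. Compound 3 `Cc1cc(NCc2ccccn2)n2ncc(-c3cc(F)c(F)c(F)c3)c2n1` also returns the limit < 5000 nM there. The steps a step that the two limits leave unreadable from compound 1 to compound 2, a step that the two limits leave unreadable from compound 1 to compound 3 and a step that the two limits leave unreadable from compound 2 to compound 3 are therefore of unreadable size, and the limit of < 5000 nM in this assay, at which 3 of the 3 values shown sit, is all the evidence the three compounds offer. Compound 4 `Cc1cc(NCc2ccccn2)n2ncc(-c3ccc(C(=O)Nc4ccccc4)cc3)c2n1` differs from compound 1 by phenylcarbamoyl in place of dimethylamino on an aromatic carbon. For the measured compounds named here, no measured step bears directly on that exchange, and the three limits give no direction. Compound 4 is expected to stay at the limit, with a step that the limit leaves unreadable from compound 1 to compound 4 expected. The estimate for compound 4 is 1500 nM, between 300 nM and 5000 nM.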

Compound 4, solubility: 5000 nM
Compound 4: the middle estimate sits 3.3-fold (0.52 log units) below what was measured; measured number inside the range.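

In this assay compound 4 gives 5000 nM, the only reading shown that is a number and not a limit. Phenylcarbamoyl in place of dimethylamino on this aromatic carbon therefore gives a number no lower from compound 1 to compound 4 (the limit leaves the size open), so the exchange shows no loss, though its size cannot be read. The series still offers little beyond one number: the limit of < 5000 nM in this assay, at which 3 of the 4 values shown sit.

Whether the phenyl ring or the amide hydrogen of phenylcarbamoyl accounts for the reading remains open. From the compounds shown here alone, it also remains open how a carboxylic acid or a morpholine at this position would read in this assay.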